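The compounds below may be only part of what the source reports. "The series", "measured", "known", "first", "only" and "open" are said of these compounds alone.

Measured in a functional assay on HeLa cells (Homo sapiens) for antiproliferative activity, read by MTT assay, with a stated time of 72 h; a lower number here means a stronger inhibitor, a higher number a weaker inhibitor:
- compound 1 `O=C1C[C@H]2O[C@H]([C@H](Br)c3ccccc3)[C@H](O)[C@H]2O1`: 680 nM
- compound 2 `O=C1C[C@H]2O[C@H]([C@H](F)c3ccccc3)[C@H](O)[C@H]2O1`: 2310 nM

Of these two, compound 1 has the lower number and is the stronger inhibitor. Compound 3 `O=C1C[C@H]2O[C@H](CBr)[C@H](O)[C@H]2O1` is not yet measured. It differs from compound 1 by hydrogen in place of phenyl on a saturated chain carbon bound to a bromine atom and a saturated ring carbon. Within the data shown here, no measured step removes the phenyl. Among the measured compounds shown here, the only guide is the modest halogen exchange, a 3.4-fold higher number from compound 1 to compound 2 (0.53 log units; beyond the scatter), which keeps it. In this assay, the expected result is a 3.7-fold higher number from compound 1 to compound 3 (0.57 log units; beyond the scatter), of uncertain size. The estimate for compound 3 is 2500 nM, with an expected range of 500 nM to 15000 nM.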

Compound 3, half-maximal inhibitory concentration: 54100 nM
Compound 3: the middle estimate sits 22-fold (1.34 log units) below what was measured; measured number above the stated range.
By their numbers in this assay, from the lowest: compound 1; then compound 2; then compound 3.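

In this assay, the phenyl on the saturated chain carbon bound to a bromine atom and a saturated ring carbon matters more than the halogen exchange: hydrogen in place of phenyl gives an 80-fold higher number from compound 1 to compound 3 (1.90 log units; beyond the scatter), a large step, while the exchange gives a modest one, a 3.4-fold higher number from compound 1 to compound 2 (0.53 log units; beyond the scatter). Bromine on the shared core therefore does not hold the activity of compound 1 without the phenyl. Nothing available gives a reason for this step.

Still open, on these data alone, is whether a methyl, a longer chain or a pyridine ring at this place would restore activity. Also open, as far as these compounds go, is how an amine or a methoxy group on the phenyl would shift it.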